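Compound 3 to compound 4: a larger aromatic group

The source may hold more compounds than are shown below. What is called first, only, known or untested is meant among the compounds shown, and "the series" means these compounds.

In a physicochemical assay for lipophilicity, using the shake flask method, measured as octanol-water partition, at pH 7.4 (on this read-out higher numbers stand for higher lipophilicity and lower numbers for lower lipophilicity), compound 1 `CC(=O)N[C@@H]1CCC[C@H](C(=O)Nc2cc(-c3cnn4c3CCCC4)c(F)cn2)C1` gives 2.9 and compound 2 `CC(=O)N[C@@H]1CCC[C@H](C(=O)Nc2cc(-c3cnn4c3CCCC4)c(Cl)cn2)C1` gives 3.2 on a closely related structure, while compound 3 `CC(=O)N[C@@H]1CCC[C@H](C(=O)Nc2cc(-c3cnn(C)c3C)c(Cl)cn2)C1` gives 2.6 in the same measurement. Compound 3 thus stands within the scatter of compound 1 and beyond the scatter below compound 2. Still unmeasured is compound 4 `CC(=O)N[C@@H]1CCC[C@H](C(=O)Nc2cc(-c3cnn4ccccc34)c(Cl)cn2)C1` which departs from compound 3 in one place. The change is a group of 9 heavy atoms (7 carbon, 2 nitrogen; one five-membered aromatic ring with 2 hetero atoms, one six-membered aromatic ring with 1 hetero atom) in place of a group of 7 heavy atoms (5 carbon, 2 nitrogen; one five-membered aromatic ring with 2 hetero atoms), on an aromatic carbon and it lies opposite the ring nitrogen.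

The step of a number 0.30 log units higher from compound 1 to compound 2 (within the scatter) swaps chloro for fluoro and does not touch this group, so it offers little guidance. The nearer guide is a number 0.60 log units lower from compound 2 to compound 3 (beyond the scatter) although the group lost there held a non-aromatic six-membered ring, whereas the entering group's ring is aromatic. Reading that step in reverse, a rise of similar or slightly smaller size is expected in this assay here. The estimated step is a number 0.50 log units higher from compound 3 to compound 4 (beyond the scatter) on this reasoning. Compound 4 is estimated at 3.1 with an expected range from 2.7 to 3.5 in this measurement.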

Compound 4, distribution coefficient: 3.6
For compound 4 the middle estimate is 0.50 log units below the measured one, outside the stated range (above it).
By their numbers in this assay, from the lowest: compounds 3, 1 and 2 (each within the scatter of the next, the first and the last beyond it); then compound 4.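

In this assay, the position opposite the ring nitrogen proved sensitive to the nature of the attached ring system, not only to its size. For the compounds shown here, replacing the 1,5-dimethyl-1H-pyrazol-4-yl group with the fused aromatic group gave a number 1.00 log units higher from compound 3 to compound 4 (beyond the scatter) and nearly double the earlier step between these kinds of groups in magnitude, while the two groups of equal heavy-atom count, one with a non-aromatic and one with an aromatic six-membered ring, are separated by a number 0.40 log units higher from compound 2 to compound 4 (beyond the scatter) as the sole change. Nothing shown gives a measured reason for either step.

As far as these compounds go, whether the fused aromatic group would give a similar step with fluoro in place of chloro remains open. So does the effect of adding an amine or a carboxylic acid to the group at this position.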